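This account rests on a few compounds, and the source may have more. Where it says the series, first, only, none or still open, it means among the compounds named here.

Compounds measured in an assay on membranes from HEK293 cells for displacement of a labelled ligand from adenosine receptor A2b (Homo sapiens), read by scintillation counting, with a stated time of 30 min, tested at 1 uM; on this read-out higher numbers stand for more inhibition at the one concentration tested (going by the name of the read-out) and lower numbers for less inhibition:
Compound 1, `COC(=O)C1=C(C)NC(=O)NC1c1cccs1`, gives 19%.
Compound 2, `CC1=C(C(=O)OC(C)(C)C)C(c2cccs2)NC(=O)N1`, gives 38%.
Compound 3, `CC1=C(C(=O)OC(C)C)C(c2ccoc2)NC(=O)N1C`, gives 37%.

Compound 3 stands second highest of the three numbers in this assay. Its nearest neighbour is compound 2, whose value lies within the scatter of that of compound 3, so the two cannot be ordered; compound 1 lies beyond the scatter below it. Compound 4, `CC1=C(C(=O)OCc2ccccc2)C(c2ccoc2)NC(=O)N1C`, has not yet been measured. Compared with compound 3 it differs in one place: benzyl in place of isopropyl on an oxygen next to a carbonyl group.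

Within the data shown here, only one measured step bears on this change, and only loosely: a number 19 percentage points higher from compound 1 to compound 2 (beyond the scatter). That step also sits on an oxygen next to a carbonyl group, but it exchanges methyl for tert-butyl rather than isopropyl for benzyl, so it is a guide to direction more than to size. On that basis compound 4 is expected to come out somewhat higher than compound 3 in this assay, by an estimated a number 8 percentage points higher from compound 3 to compound 4 (within the scatter). The estimate for compound 4 is 45%, with a range from 25% to 65%.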

Compound 4, a percentage reported as inhibition, at one concentration (the size of the read-out at that concentration, not a potency): 49%
For compound 4 the middle estimate is 4 percentage points below the measured one; the measured number falls inside the stated range.
By their numbers in this assay, from the lowest: compound 1; then compounds 3 and 2 (each within the scatter of the next); then compound 4.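

In this assay, the change from isopropyl to benzyl on an oxygen next to a carbonyl group gives a number 12 percentage points higher from compound 3 to compound 4 (beyond the scatter), so this place accepts a group carrying a six-membered aromatic ring of carbon only, and the number rises. Among these compounds, until now the only step at this place was a number 19 percentage points higher from compound 1 to compound 2 (beyond the scatter), an exchange between two groups with no ring, made on a different pair of compounds; the rise now also appears with a ring-bearing group. Nothing measured here accounts for this rise.

The compounds shown leave open whether the gain belongs to the aromatic ring itself or to the larger count of heavy atoms, which cyclohexylmethyl at the same place could separate. They also leave open how a longer chain such as phenethyl, or a chain ending in an amine or a carboxylic acid, would read here, and whether benzyl gives a similar step on the core of compound 1.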